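The compounds below may be only part of what the source reports. "The series", "measured", "known", "first", "only" and "open" are said of these compounds alone.

Measured so far in a physicochemical assay for lipophilicity, using the shake flask method, at pH 7.4 (a lower number here means a more polar compound, a higher number a more lipophilic compound), are three compounds:
- compound 1 `O=C(O)CCNC(=O)c1ccc(C(Oc2ccc(-n3cc(C(F)(F)F)cn3)cc2)C2CC2)cc1` gives 1.7
- compound 2 `CCCC(Oc1ccc(-n2cc3ccccc3n2)cc1)c1ccc(C(=O)NCCC(=O)O)cc1` gives 2.5
- compound 3 `CCCC(Oc1ccc(-n2cc(C(F)(F)F)c(C)n2)cc1)c1ccc(C(=O)NCCC(=O)O)cc1` gives 2.8

Compound 1 stands lowest of the three, and its value lies beyond the scatter from those of both compound 2 and compound 3. The next compound to be measured, compound 4 `CCC(Oc1ccc(-n2cc(C(F)(F)F)cn2)cc1)c1ccc(C(=O)NCCC(=O)O)cc1`, keeps the core of compound 1 and alters one group (ethyl in place of cyclopropyl on a saturated chain carbon bound to an aromatic carbon and an oxygen on an aromatic ring).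

Going by the values given here, no measured step covers this change. Among the compounds with values here, the only step available (a number 0.30 log units higher from compound 2 to compound 3 (within the scatter)) puts 3-methyl-4-(trifluoromethyl)-1H-pyrazol-1-yl in place of 2H-indazol-2-yl on an aromatic carbon, which is a different place in the molecule. Compound 2 and compound 3 also differ from compound 1 in more than one place, so their higher values cannot be assigned to any single group. Only a small upward step, not beyond the scatter, is therefore expected in this assay. The expected change is a number 0.20 log units higher from compound 1 to compound 4 (within the scatter) in this measurement. The estimated value for compound 4 is 1.9 (expected range 1.5 to 2.3).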

Compound 4, distribution coefficient: 1.9
Compound 4: the middle estimate sits on the measured number at the digits printed; measured number inside the range.
By their numbers in this assay, from the lowest: compounds 1 and 4 (each within the scatter of the next); then compounds 2 and 3 (each within the scatter of the next).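

Replacing cyclopropyl with ethyl on the saturated chain carbon bound to an aromatic carbon and an oxygen on an aromatic ring gives, in this assay, a number 0.20 log units higher from compound 1 to compound 4 (within the scatter). Going by these compounds alone, this is the first step measured at this position, as the only earlier step concerned a different place in the molecule. On the core of compound 1, the loss of the three-membered ring and the change from 3 to 2 heavy atoms therefore leave the two compounds within the scatter of each other, and no separate evidence bears on the reason for this result.

The compounds shown leave open how this position responds to groups of another kind, such as an amine, a hydroxyl group or a longer chain, as only cyclopropyl and ethyl form a pair that differs here alone. They also leave open whether the same exchange would give a similar step with 2H-indazol-2-yl or 3-methyl-4-(trifluoromethyl)-1H-pyrazol-1-yl on the aromatic carbon, where the present pair offers no reading.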